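Compound 4 and the methyl step from compound 3

A few compounds are considered here, and "the series" means these few. Any claim that something is new, unique, unknown or untested is made for them only; others in the source may bear on it.

Measured in a functional assay on P388 cells (Mus musculus); a lower number here means a stronger inhibitor, a higher number a weaker inhibitor:
- compound 1 `O=C(/C=C/c1ccc(Cl)c(Cl)c1)Oc1ccc(/C=C2\CCCCC2=O)cc1` gives > 50000 nM (a limit)
- compound 2 `COc1ccc(/C=C/C(=O)Oc2ccc(/C=C3\CCCC(CN(C)C)C3=O)cc2)cc1` gives 2410 nM
- compound 3 `O=C1CCCC/C1=C\c1ccc(OC(=O)c2ccccc2)cc1` gives > 50000 nM (a limit)

Compound 3 sits with the limit of > 50000 nM in this assay, at which 2 of the 3 values shown sit, and so has no number. Compound 4 `Cc1ccc(C(=O)Oc2ccc(/C=C3\CCCCC3=O)cc2)cc1` differs from it by methyl in place of hydrogen on an aromatic carbon, para to a large group methyl in place of hydrogen on an aromatic carbon and nothing else. Among the compounds with values here, no measured pair shows this change. The expectation therefore rests on compound 3 alone, whose limit is > 50000 nM and not a number. In this assay the expected change is none beyond the scatter, in no clear direction, with the estimated step of a number no higher from compound 3 to compound 4 (the limit leaves the size open) as its size. Compound 4 is estimated at 50000 nM within 20000 nM to 100000 nM and may well again report only a limit.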

Compound 4, half-maximal inhibitory concentration: > 50000 nM
Compound 4: no number, only a limit; the forecaster's own chance of this, stated with the estimate: 75%; the middle value lies on the limit itself.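

No step can be read from compound 3 to compound 4 in this assay, since each of the two reports only a limit: the limit of > 50000 nM in this assay, at which 3 of the 4 values shown sit.

The compounds shown leave open whether methyl in place of hydrogen changes inhibition at all.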